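Replacing methanesulfonamido on the shared core

A few compounds are considered here, and "the series" means these few. Any claim that something is new, unique, unknown or untested is made for them only; others in the source may bear on it.

Values in a physicochemical assay for solubility, measured as thermodynamic solubility, at pH 6.5; on this read-out lower numbers stand for lower solubility and higher numbers for higher solubility:
- compound 1 `CS(=O)(=O)Cc1ccc(C(=O)Nc2ccc(Cl)c(-c3ccccn3)c2)c(Cl)c1`: 3 ug/mL
- compound 2 `CS(=O)(=O)Nc1ccc(C(=O)Nc2ccc(Cl)c(-c3ccccn3)c2)c(Cl)c1`: 1 ug/mL
- compound 3 `O=C(NCc1ccccn1)c1ccc(C(=O)Nc2ccc(Cl)c(-c3ccccn3)c2)c(Cl)c1`: not yet measured

Within the data shown here, compound 2, at 1 ug/mL, holds the lower of the two numbers so far, and the only other number comes from compound 1 at 3 ug/mL.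

The next change is ((pyridin-2-yl)methyl)carbamoyl in place of methanesulfonamido on an aromatic carbon. In words, ((pyridin-2-yl)methyl)carbamoyl comes in place of methanesulfonamido on an aromatic carbon, meta to a chloro group and para to a large group.

Among the measured compounds shown here, one measured step bears on this: a 3.0-fold lower number from compound 1 to compound 2 (0.48 log units; beyond the scatter). It is modest, though beyond the scatter, and it also involves methanesulfonamido on an aromatic carbon. For the measured compounds named here, no measured compound carries the entering group, so the data give no direct guide to direction. Going by the values given here, with only two closely spaced numbers in this assay, a step of similar modest size is expected, leaning slightly upward from the floor of the series so far. The expected step is a 2.0-fold higher number from compound 2 to compound 3 (0.30 log units; within the scatter).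

For compound 3 the estimate is 2 ug/mL, with an expected range of 0.5 ug/mL to 8 ug/mL.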

Compound 3, solubility: 3 ug/mL
For compound 3 the middle estimate is 1.5-fold (0.18 log units) below the measured one, and the stated range covers the measured number.
By their numbers in this assay, from the lowest: compound 2; then compounds 1 and 3 (each within the scatter of the next).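

At this position, on an aromatic carbon meta to a chloro group and para to a large group, this assay now has a reading for an entering group that carries a six-membered aromatic ring: ((pyridin-2-yl)methyl)carbamoyl in place of methanesulfonamido gives a 3.0-fold higher number from compound 2 to compound 3 (0.48 log units; beyond the scatter). Against the (methylsulfonyl)methyl group, the same entering group gives no change at the digits printed from compound 1 to compound 3 (within the scatter), so among these three compounds only the methanesulfonamido compound stands apart, and the extra bulk of the ring-bearing amide brings no step beyond the scatter relative to the (methylsulfonyl)methyl compound. Nothing shown here accounts for either step.

Open, going by these compounds, is whether the ring nitrogen of the pyridin-2-yl group matters, which a plain benzyl carbamoyl group or a shorter methyl carbamoyl group at the same place would begin to test. Also open, on these data alone, is whether a carboxylic acid or a dimethylaminomethyl group at this position would lift the reading in this assay clear of the narrow band that compound 1, compound 2 and compound 3 occupy.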